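Compound 2 and Its Mirror Image, Compound 3

The compounds below may be only part of what the source reports. "The series", "measured", "known", "first", "only" and "open" are said of these compounds alone.

In a toxicity assay on Hepa-1c1c7 cells (Mus musculus) for inhibition (a lower number here means a stronger inhibitor, a higher number a weaker inhibitor), compound 1 (`CCCCC[C@@H](O)C#CC#CCO`) reads > 100000 nM as a limit of the assay and not a number. Within the data shown here, compound 2 (`CCCCC[C@H](O)C#CC#C[C@@H](O)CCCCC`) gives 47000 nM as the only true number so far, and this makes it the reference point for what follows. Compound 3 (`CCCCC[C@@H](O)C#CC#C[C@H](O)CCCCC`) has not yet been measured. Its relation to compound 2 is simple to state (the two compounds have the same atoms and bonds and differ only in configuration as drawn: 2 of 2 stereo elements differ (all stereocentres are inverted: mirror images); a stereocentre at a saturated chain carbon is drawn S in compound 2 and R in compound 3; a stereocentre at a saturated chain carbon is drawn S in compound 2 and R in compound 3). The two compounds have the same atoms and bonds and differ only in configuration as drawn. All stereocentres are inverted, so they are mirror images, with each stereocentre at a saturated chain carbon drawn S in compound 2 and R in compound 3. Among the measured compounds shown here, no measured pair of mirror images is available as a guide, so any forecast rests on compound 2 at 47000 nM alone. The expected step (a 1.2-fold lower number from compound 2 to compound 3 (0.07 log units; within the scatter)) is no larger than the usual scatter, with no firm direction. In this assay the estimated value for compound 3 is 40000 nM with an expected range from 10000 nM to 100000 nM around it.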

Compound 3, half-maximal inhibitory concentration: 12000 nM
Estimate against measurement, compound 3: 3.3-fold (0.52 log units) above; the measured number falls inside the stated range.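

Among these compounds, compounds 2 and 3 form the first measured pair of mirror images in this assay, and inverting both stereocentres from S to R gives a 3.9-fold lower number from compound 2 to compound 3 (0.59 log units; beyond the scatter), so the drawn configuration alone shifts the reading by more than repeat measurements would. No other change in structure can account for this step, as the comparison rests on this: the fact that compounds 2 and 3 differ only in the configuration as drawn

Compound 1 reads > 100000 nM, which is a limit of the assay and not a number. Pentyl in place of hydrogen on a saturated chain carbon bound to an oxygen on a saturated carbon and a triple-bonded carbon gives an at least 8.3-fold lower number from compound 1 to compound 3 (0.92 log units; beyond the scatter), and the true size of this step stays unknown for the following reason: the limit of > 100000 nM in this assay, at which 1 of the 3 values shown sits.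

The compounds shown leave open whether inverting a single stereocentre would carry part of the step or all of it, as the only mirror-image comparison here inverts both at once. They also leave open how a longer chain in place of pentyl, or an amine in place of a hydroxyl group, would read in this assay.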